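Compound 3 to compound 4: changing the ketone aryl group

The source may hold more compounds than are shown below. What is called first, only, known or untested is meant among the compounds shown, and "the series" means these compounds.

Values in a functional assay on NCI-H460 cells (Homo sapiens) for antiproliferative activity, read by XTT assay, with a stated time of 72 h (a lower number here means a stronger inhibitor, a higher number a weaker inhibitor), for the measured compounds
compound 1 `COc1ccc(-c2cc3ccccc3nc2/C=C/C(=O)c2ccccc2)cc1` gives 6670 nM
compound 2 `COc1ccc(-c2cc3ccccc3nc2/C=C/C(=O)c2c(OC)cccc2OC)cc1` gives 6630 nM
compound 3 `COc1ccc(-c2cc3ccccc3nc2/C=C/C(=O)c2ccc(N)cc2)cc1` gives 7400 nM

Compound 3 stands level with compound 1 and compound 2, and the three numbers are not separated beyond the scatter. The next change is 5-bromothiophen-2-yl in place of 4-aminophenyl on a carbonyl carbon and leads to the unmeasured compound 4 `COc1ccc(-c2cc3ccccc3nc2/C=C/C(=O)c2ccc(Br)s2)cc1` by placing 5-bromothiophen-2-yl in place of 4-aminophenyl on a carbonyl carbon.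

For the measured compounds named here, three measured steps bear on this change. Replacing the group on the carbonyl carbon gives a 1.0-fold lower number from compound 1 to compound 2 (0.00 log units; within the scatter) and also a 1.1-fold higher number from compound 2 to compound 3 (0.05 log units; within the scatter) in the series. Amino in place of hydrogen on an aromatic carbon gives a 1.1-fold higher number from compound 1 to compound 3 (0.05 log units; within the scatter) as the third step. Going by the values given here, all three lie within the scatter, and no measured compound goes against this flat picture. Among the compounds with values here, still, no measured compound carries a five-membered aromatic ring or a bromine, and the flat picture rests on only three compounds.

In this assay the expected step is a 1.2-fold lower number from compound 3 to compound 4 (0.09 log units; within the scatter) and no change beyond the scatter is expected in either direction. The estimated value for compound 4 is 6000 nM with an expected range from 2500 nM to 14000 nM as a deliberately wide span.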

Compound 4, half-maximal inhibitory concentration: 5170 nM
Compound 4: the middle estimate sits 1.2-fold (0.06 log units) above what was measured; the measured number falls inside the stated range.
By their numbers in this assay, from the lowest: compounds 4, 2, 1 and 3 (each within the scatter of the next).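

Working notes, carbonyl position: in this assay, the group on the carbonyl carbon can be a five-membered aromatic ring bearing bromine and sulfur, rather than a six-membered aromatic ring of carbon only, and the result stays flat, with a 1.4-fold lower number from compound 3 to compound 4 (0.16 log units; within the scatter). The comparisons with the two other aryl ketones read the same, with a 1.3-fold lower number from compound 2 to compound 4 (0.11 log units; within the scatter) and a 1.3-fold lower number from compound 1 to compound 4 (0.11 log units; within the scatter), so phenyl, 2,6-dimethoxyphenyl, 4-aminophenyl and 5-bromothiophen-2-yl are not separated at this position, and no compound shown goes against this. No measurement shown accounts for this flat result.

As far as these compounds go, it remains open whether any group on this carbonyl carbon can move the number beyond the scatter, for example a saturated ring amine such as piperidine in place of the aromatic ring, or a carboxylic acid on the aryl ring. The compounds shown also vary only this one position, so they say nothing about changes to the double-bonded chain or the shared core, or about whether the flat picture holds for those changes.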